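The compounds below may be only part of what the source reports. "The series", "measured", "known", "first", "only" and "open" are said of these compounds alone.

The compounds measured so far:

compound 1, `CC1CN(S(=O)(=O)C[C@]23CC[C@H](CC2=O)C3(C)C)CCN1c1ccc(C(F)(F)F)cn1`: 316 nM
compound 2, `CC1CN(c2ccc(C(F)(F)F)cn2)CCN1S(=O)(=O)C[C@]12CC[C@H](CC1=O)C2(C)C`: 631 nM
compound 3, `CC1(C)[C@@H]2CC[C@@]1(CS(=O)(=O)N1CCN(c3ccccn3)CC1)C(=O)C2`: > 31600 nM

In a functional assay on CHO-K1 cells for antagonist activity at C-X-C chemokine receptor type 3 (Homo sapiens), read by FLIPR and calcium flux (on this read-out higher numbers stand for weaker inhibition and lower numbers for stronger inhibition), compound 1 gives 316 nM. Compound 2 gives 631 nM in this assay, and these two values lie within the usual scatter of each other. Compound 3 is different in kind: its entry of > 31600 nM in this assay is a limit of the assay and not a number, the case described by the limit of > 31600 nM in this assay, at which 1 of the 3 values shown sits. Compound 3 therefore stands at the edge of what this assay reports, whereas compound 1 and compound 2 each return a measured number.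

Compound 4, `CC1(C)[C@@H]2CC[C@@]1(CS(=O)(=O)N1CCN(c3ccc(C#N)cn3)CC1)C(=O)C2`, has not yet been measured in this assay. It differs from compound 3 by cyano in place of hydrogen on an aromatic carbon. Going by the values given here, no pair of measured compounds isolates this change; compound 1 and compound 2 differ from compound 3 in more than one place, so their values show only that other substitution on this part of the structure goes with a measured number rather than a limit.

On that basis the step from compound 3 to compound 4 is expected to run toward stronger inhibition, an at least 7.9-fold lower number from compound 3 to compound 4 (0.89 log units; beyond the scatter), though with wide uncertainty since compound 3 sets only a limit. Compound 4 is accordingly estimated at 4000 nM in this assay, within a range from 800 nM to 20000 nM.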

Compound 4, half-maximal inhibitory concentration: > 31600 nM
Compound 4 was reported as a limit; the forecaster's own chance of this, stated with the estimate: 25%; middle value at least 7.9-fold (0.89 log units) from the limit.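

In this assay compound 4 gives > 31600 nM, which is a limit of the assay and not a number. Compound 3 also stands at a limit, so no step can be read between compound 3 and compound 4: the limit of > 31600 nM in this assay, at which 2 of the 4 values shown sit.

The compounds shown leave open how far, if at all, cyano in place of hydrogen shifts inhibition.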